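From Dichloro to Dimethyl on the Benzamide Ring

The source may report more compounds than this note shows. Statements on the series, on what has been measured and on what is new or still open speak of the compounds shown alone.

Three compounds have so far been measured in a functional assay on MCF7 cells (Homo sapiens) for antiproliferative activity, read by MTT assay, with a stated time of 48 h; on this read-out lower numbers stand for stronger inhibition and higher numbers for weaker inhibition:

compound 1 `O=C(Nc1cccc(/C=C/C(=O)c2nc3ccccc3[nH]2)c1)c1ccccc1`: 11200 nM
compound 2 `Cc1ccc(C(=O)Nc2cccc(/C=C/C(=O)c3nc4ccccc4[nH]3)c2)cc1`: 9690 nM
compound 3 `O=C(Nc1cccc(/C=C/C(=O)c2nc3ccccc3[nH]2)c1)c1cc(Cl)cc(Cl)c1`: > 100000 nM

For compound 3 this value is a limit of the assay and not a number. Compound 4 `Cc1cc(C)cc(C(=O)Nc2cccc(/C=C/C(=O)c3nc4ccccc4[nH]3)c2)c1` differs from compound 3 by 3,5-dimethylphenyl in place of 3,5-dichlorophenyl on a carbonyl carbon. Among the compounds with values here, the steps that bear on this change are an at least 8.9-fold higher number from compound 1 to compound 3 (0.95 log units; beyond the scatter) and an at least 10-fold higher number from compound 2 to compound 3 (1.01 log units; beyond the scatter), both well beyond the scatter, whereas a 1.2-fold lower number from compound 1 to compound 2 (0.06 log units; within the scatter) shows that a methyl on this ring changes little. Removing the two chlorines is thus expected to lower the number in this assay, bringing compound 4 nearer to compounds 1 and 2. The expected step is an at least 5.0-fold lower number from compound 3 to compound 4 (0.69 log units; beyond the scatter). Compound 4 is estimated at 20000 nM, in the range 6000 nM to 100000 nM.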

Compound 4, half-maximal inhibitory concentration: 24600 nM
Estimate against measurement, compound 4: 1.2-fold (0.09 log units) below, within the range that was stated.
By their numbers in this assay, from the lowest: compounds 2 and 1 (each within the scatter of the next); then compound 4. At a limit, above all of these: compound 3.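

In this assay, 3,5-dimethylphenyl in place of 3,5-dichlorophenyl gives an at least 4.0-fold lower number from compound 3 to compound 4 (0.60 log units; beyond the scatter) and so shows that two substituents on this ring do not by themselves reach the limit. Compound 3 stands at a limit of the assay, so this step has only a lower bound: the limit of > 100000 nM in this assay, at which 1 of the 4 values shown sits. The ring still has a modest cost, with a 2.2-fold higher number from compound 1 to compound 4 (0.34 log units; beyond the scatter) and a 2.5-fold higher number from compound 2 to compound 4 (0.40 log units; beyond the scatter) in the same assay.

On these data alone, whether a single chlorine, a methoxy group or an amine on this ring would stay near compound 1 or move towards compound 3 remains open.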